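Benzyl in place of aryl on the amide-type nitrogen

The source may hold more compounds than are shown below. What is called first, only, known or untested is meant among the compounds shown, and "the series" means these compounds.

Among the compounds with values here, compound 1 `COc1cccc(NC(=O)/C=C/c2coc3cc(OC)ccc3c2=O)c1` is the only member of this set with a numerical reading: in a functional assay on Huh-7 cells (Homo sapiens) for inhibition, read by MTT assay, with a stated time of 48 h (a lower number here means a stronger inhibitor, a higher number a weaker inhibitor), compound 1 gives 11100 nM. Compound 2 `COc1ccc(NC(=O)/C=C/c2coc3cc(O)ccc3c2=O)cc1` carries a 4-methoxyphenyl on the amide-type nitrogen; in this assay compound 2 gives > 100000 nM, which is a limit of the assay and not a number. Compound 3 `Cc1ccc(CNC(=O)/C=C/c2coc3cc(O)ccc3c2=O)cc1` carries a 4-methylbenzyl on that nitrogen; in this assay compound 3 gives > 100000 nM, again only a limit. The step that the two limits leave unreadable from compound 2 to compound 3 is therefore unreadable, since both ends rest on (the limit of > 100000 nM in this assay, at which 2 of the 3 values shown sit).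

Compound 4 `COc1ccc2c(=O)c(/C=C/C(=O)NCc3ccc(F)cc3F)coc2c1` is not yet measured. It differs from compound 1 by 2,4-difluorobenzyl in place of 3-methoxyphenyl on an amide-type nitrogen. Within the data shown here, the only measured step of the same kind, aryl to benzyl on the amide-type nitrogen, is the unreadable one, so no direction or size can be taken from it; the benzyl analogue compound 3 sits at the limit, which leaves a real chance that compound 4 does too. Compound 4 is expected near 30000 nM, within 7000 nM to 120000 nM. The expected step is a 2.7-fold higher number from compound 1 to compound 4 (0.43 log units; beyond the scatter).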

Compound 4, half-maximal inhibitory concentration: > 100000 nM
Compound 4: no number, only a limit; the forecaster's own chance of this, stated with the estimate: 40%; at least 3.3-fold (0.52 log units) between middle value and limit.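

With the rest of compound 1 unchanged, 2,4-difluorobenzyl in place of 3-methoxyphenyl on the amide-type nitrogen gives a clear loss in this assay, with an at least 9.0-fold higher number from compound 1 to compound 4 (0.95 log units; beyond the scatter). Within the data shown here, the earlier step from aryl to benzyl on this nitrogen could not be read, so this is the first step here with a direction. Compound 4 gives > 100000 nM, a limit of the assay and not a number, so the size of the step is only a lower bound, and the set now rests largely on one limit: the limit of > 100000 nM in this assay, at which 3 of the 4 values shown sit.

The compounds shown do not separate the loss of the methoxy group from the change from phenyl to benzyl or from the two fluorines. On these data alone, how an unsubstituted benzyl, or a longer chain ending in an amine, would read on this nitrogen remains open.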